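From pyridin-3-yl to 5-methoxypyridin-3-yl in compound 3

A few compounds are considered here, and "the series" means these few. Any claim that something is new, unique, unknown or untested is made for them only; others in the source may bear on it.

Within the data shown here, in an ADME assay (liver) for metabolic stability, with Liver microsome (Rattus norvegicus) as the target, using microsomes and NADPH, with a stated time of 30 min, tested at 1 uM (on this read-out lower numbers stand for slow clearance and higher numbers for fast clearance), compound 1 `Nc1ccc(S(=O)(=O)N2CCN(c3ncc(C(O)(C(F)(F)F)C(F)(F)F)cc3-c3cccc(F)c3)CC2)cn1` gives 52 mL.min-1.g-1 while compound 2 `Nc1ccc(S(=O)(=O)N2CCN(c3ncc(C(O)(C(F)(F)F)C(F)(F)F)cc3-c3cccnc3)CC2)cn1` gives 20 mL.min-1.g-1 as the lower of the two numbers so far. Among the measured compounds shown here, the single measured step, a 2.6-fold lower number from compound 1 to compound 2 (0.41 log units; beyond the scatter) with pyridin-3-yl in place of 3-fluorophenyl on an aromatic carbon, is modest but beyond the scatter. Compound 3 `COc1cncc(-c2cc(C(O)(C(F)(F)F)C(F)(F)F)cnc2N2CCN(S(=O)(=O)c3ccc(N)nc3)CC2)c1` keeps the rest of compound 2 and carries methoxy in place of hydrogen on an aromatic carbon two atoms from the ring nitrogen. For the measured compounds named here, no measured step adds methoxy, so the step to compound 2 offers only a rough guide to size. A small rise is expected, smaller than that measured step, and the estimated change is a 1.5-fold higher number from compound 2 to compound 3 (0.18 log units; within the scatter) in this assay for this pair. Compound 3 is expected at 30 mL.min-1.g-1 with an estimated range of 14 mL.min-1.g-1 to 65 mL.min-1.g-1 in that assay.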

Compound 3, intrinsic clearance in microsomes: 58 mL.min-1.g-1
Compound 3: the middle estimate sits 1.9-fold (0.29 log units) below what was measured, and the stated range covers the measured number.
By their numbers in this assay, from the lowest: compound 2; then compounds 1 and 3 (each within the scatter of the next).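

On the pyridin-3-yl ring of compound 2, this position turns out not to be neutral: in this assay, methoxy in place of hydrogen gives a 2.9-fold higher number from compound 2 to compound 3 (0.46 log units; beyond the scatter), a step beyond the scatter and the first one measured at this place. The lower number seen with pyridin-3-yl therefore does not carry over to 5-methoxypyridin-3-yl, since the comparison with the 3-fluorophenyl compound gives a 1.1-fold higher number from compound 1 to compound 3 (0.05 log units; within the scatter) and leaves the two compounds indistinguishable on this read-out. Nothing available here accounts for the effect of methoxy at this position.

The compounds shown do not tell whether the rise follows from methoxy alone or from any group placed on this aromatic carbon. An amine, a nitrile or a longer chain such as ethoxy at the same place could settle that question.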